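The source may hold more compounds than are shown below. What is called first, only, known or untested is meant among the compounds shown, and "the series" means these compounds.

Measured compounds in a functional assay on HPAC cells (Homo sapiens) for inhibition, read by MTT assay, with a stated time of 72 h; on this read-out lower numbers stand for stronger inhibition of growth and higher numbers for weaker inhibition of growth:
compound 1, `COc1ccc(CNCCCNS(=O)(=O)c2cc(C(F)(F)F)cc(C(F)(F)F)c2)cc1OC`, 3500 nM
compound 2, `O=S(=O)(NCCCNCc1ccc(Cl)c(C(F)(F)F)c1)c1cc(C(F)(F)F)cc(C(F)(F)F)c1`, 3000 nM
compound 3, `CN(CCCNS(=O)(=O)c1cc(C(F)(F)F)cc(C(F)(F)F)c1)Cc1ccccc1`, 30000 nM

Compound 1 has the second highest of the three numbers. Compound 2 stands nearest to it, within the scatter; compound 3 has the highest number, and its gap to compound 1 lies beyond the scatter. Compound 4, `O=S(=O)(NCCCNCc1ccc(Cl)c(Cl)c1)c1cc(C(F)(F)F)cc(C(F)(F)F)c1`, has not yet been measured in this assay. It differs from compound 1 in one place: 3,4-dichlorophenyl in place of 3,4-dimethoxyphenyl on a saturated chain carbon bound to an amine nitrogen.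

Going by the values given here, the one measured step that bears on this change is a 1.2-fold lower number from compound 1 to compound 2 (0.07 log units; within the scatter), where the 3,4-dimethoxyphenyl was likewise exchanged for a halogenated phenyl, 4-chloro-3-(trifluoromethyl)phenyl, on the saturated chain carbon bound to the amine nitrogen. That exchange left the number within the scatter. Compound 3 differs from compound 1 in a different way and does not bear on this step. Exchanging the 3,4-dimethoxyphenyl for 3,4-dichlorophenyl is therefore expected to give no step beyond the scatter in this assay, in either direction, with the number of compound 2 as the closer guide. The expected value for compound 4 is 3000 nM, with a range of 1400 nM to 6500 nM. The step expected from this estimate is a 1.2-fold lower number from compound 1 to compound 4 (0.07 log units; within the scatter).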

Compound 4, concentration for 50% growth inhibition: 2500 nM
For compound 4 the middle estimate is 1.2-fold (0.08 log units) above the measured one; low and high end bracket the measured number.
By their numbers in this assay, from the lowest: compounds 4, 2 and 1 (each within the scatter of the next); then compound 3.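

In this assay, 3,4-dichlorophenyl in place of 3,4-dimethoxyphenyl on a saturated chain carbon bound to an amine nitrogen gives a 1.4-fold lower number from compound 1 to compound 4 (0.15 log units; within the scatter), so going from 2 hydrogen-bond acceptors to 0 on this group leaves the number within the scatter. Chloro in place of trifluoromethyl on an aromatic carbon gives a 1.2-fold lower number from compound 2 to compound 4 (0.08 log units; within the scatter), so these two halogenated groups also cannot be told apart in this read-out. The one step here beyond the scatter is a 12-fold lower number from compound 3 to compound 4 (1.08 log units; beyond the scatter), but (3,4-dichlorobenzyl)amino in place of benzyl(methyl)amino changes the ring chlorines and the methyl on the amine nitrogen together, and the compounds shown cannot assign the step to either.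

Nothing at hand gives a reason for any of these steps. Still open, going by these compounds, is how a plain benzyl on the same secondary amine would read, which would separate the ring chlorines from the methyl, and how a longer chain on the sulfonamide nitrogen would read with the 3,4-dichlorobenzyl kept.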